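Methylating one hydroxy of compound 1

The source may report more compounds than this note shows. Statements on the series, on what has been measured and on what is new or still open speak of the compounds shown alone.

In a functional assay on MCF7 cells (Homo sapiens) for inhibition, read by MTT assay, with a stated time of 2 days (on this read-out lower numbers stand for stronger inhibition and higher numbers for weaker inhibition), compound 1 (`Oc1ccc(/C=C/c2cccc(O)c2)cc1`) gives 23 ug/mL. Compound 2 (`Nc1ccccc1/C=C/c1cccc(O)c1`) gives 17 ug/mL, within the scatter of compound 1. For the measured compounds named here, compound 3 (`Nc1cccc(/C=C/c2ccc(O)cc2)c1`) gives 6 ug/mL, the only value beyond the scatter from compound 1. Compound 4 (`COc1ccc(/C=C/c2cccc(O)c2)cc1`) arises from compound 1 by methyl in place of hydrogen on an oxygen on an aromatic ring, hydroxy to methoxy. Going by the values given here, the one measured step, a 3.8-fold lower number from compound 1 to compound 3 (0.58 log units; beyond the scatter), replaces the other hydroxy, which compound 4 keeps, so it bears only indirectly. Compound 2 also keeps that hydroxy and lacks the one changed here, yet gives 17 ug/mL. No step beyond the scatter is therefore expected in this assay. The estimated change is a 1.4-fold lower number from compound 1 to compound 4 (0.16 log units; within the scatter). Compound 4 is expected at 16 ug/mL, with an estimated range of 6 ug/mL to 40 ug/mL.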

Compound 4, half-maximal inhibitory concentration: 21 ug/mL
Compound 4: the middle estimate sits 1.3-fold (0.12 log units) below what was measured, within the range that was stated.
By their numbers in this assay, from the lowest: compound 3; then compounds 2, 4 and 1 (each within the scatter of the next).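

The methyl in place of hydrogen on this oxygen leaves the number in this assay essentially unmoved, with a 1.1-fold lower number from compound 1 to compound 4 (0.04 log units; within the scatter) staying within the scatter. For the compounds shown here, this position therefore tolerates hydroxy to methoxy, whereas the only earlier step, a 3.8-fold lower number from compound 1 to compound 3 (0.58 log units; beyond the scatter), changed the other hydroxy and lay beyond the scatter. Nothing available explains why this change has so little effect.

The compounds shown leave open whether a longer chain on this oxygen, such as ethyl or benzyl, would also pass unnoticed. They also leave open how a carboxylic acid in place of this hydroxy would read.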